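Compound 3 Expected Near Compound 2

The compounds below may be only part of what the source reports. "The series", "measured", "known", "first", "only" and "open" are said of these compounds alone.

In a functional assay on MKN-45 cells (Homo sapiens) for cytotoxicity, read by MTT assay, with a stated time of 72 h (on this read-out higher numbers stand for weaker inhibition and lower numbers for stronger inhibition), compound 2 `Cc1cc(/C=N/NC(=O)Nc2ccc(Oc3ccnc(-c4nncn4CCN(C)C)c3)c(F)c2)cc(C)c1O` gives 1510 nM and compound 1 `CN(C)CCn1cnnc1-c1cc(Oc2ccc(NC(=O)N/N=C/c3ccc(O)cc3)cc2F)ccn1` gives 820 nM; the two lie within the scatter of each other, so no order between them can be claimed. Compound 3 `CN(C)CCn1cnnc1-c1cc(Oc2ccc(NC(=O)N/N=C/c3ccc(O)cc3O)cc2F)ccn1` differs from compound 2 by 2,4-dihydroxyphenyl in place of 4-hydroxy-3,5-dimethylphenyl on a carbon with a double bond to nitrogen. Within the data shown here, the only measured step on this ring, a 1.8-fold higher number from compound 1 to compound 2 (0.27 log units; within the scatter), stayed within the scatter, and no measured step brings in a second hydroxyl. A step of about a 1.5-fold lower number from compound 2 to compound 3 (0.18 log units; within the scatter) is therefore expected, nothing beyond the scatter. Compound 3 is estimated at 1000 nM, with a range from 400 nM to 2500 nM.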

Compound 3, half-maximal inhibitory concentration: 2860 nM
For compound 3 the middle estimate is 2.9-fold (0.46 log units) below the measured one, outside the stated range (above it).
By their numbers in this assay, from the lowest: compounds 1, 2 and 3 (each within the scatter of the next, the first and the last beyond it).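

In this assay, among these compounds, hydroxy in place of hydrogen on an aromatic carbon gives the first step on this ring beyond the scatter, though a modest one (a 3.5-fold higher number from compound 1 to compound 3 (0.54 log units; beyond the scatter)). The change from 4-hydroxy-3,5-dimethylphenyl to 2,4-dihydroxyphenyl stays within the scatter (a 1.9-fold higher number from compound 2 to compound 3 (0.28 log units; within the scatter)), so only the added hydroxyl separates two compounds here. Nothing available explains this step. The compounds shown leave open whether a methoxy or an amine in place of the second hydroxyl would give a similar number. They also leave open whether a hydroxyl elsewhere on this ring would.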